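The compounds below may be only part of what the source reports. "The series", "measured", "known", "first", "only" and "open" are said of these compounds alone.

In an in vitro ADME assay on microsomes from liver (Mus musculus) for pharmacokinetics, read by LC-MS, with a stated time of 10 min, tested at 1 uM (a lower number here means slower removal, a higher number faster removal of the compound), compound 1 (`CN1C[C@H](C(=O)NC2CCCC2)[C@@H](c2ccc(/C=C/C(=O)Nc3ccccc3N)cc2)C1`) gives 61 mL/min/kg, compound 2 (`Nc1ccccc1NC(=O)/C=C/c1ccc([C@H]2CN(C3COC3)C[C@@H]2C(=O)Nc2ccc(Cl)cc2)cc1`) gives 42 mL/min/kg, and compound 3 (`CC(C)(C)N1C[C@H](C(=O)Nc2ccc(Cl)cc2)[C@@H](c2ccc(/C=C/C(=O)Nc3ccccc3N)cc2)C1`) gives 20 mL/min/kg, the lowest of the three numbers. Compound 4 (`N#CCN1C[C@H](C(=O)Nc2ccc(Cl)cc2)[C@@H](c2ccc(/C=C/C(=O)Nc3ccccc3N)cc2)C1`) carries a single change from compound 3: cyanomethyl in place of tert-butyl on an amine nitrogen in a ring. For the measured compounds named here, only one measured step touches this nitrogen, a modest one: a 2.1-fold lower number from compound 2 to compound 3 (0.32 log units; beyond the scatter). Going by the values given here, that step brought in the tert-butyl group, and no measured step shows cyanomethyl. A step of similar size in the opposite direction is therefore expected, an estimated 1.8-fold higher number from compound 3 to compound 4 (0.26 log units; within the scatter). For compound 4 the estimate is 36 mL/min/kg, with an expected range from 20 mL/min/kg to 65 mL/min/kg.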

Compound 4, clearance: 51 mL/min/kg
For compound 4 the middle estimate is 1.4-fold (0.15 log units) below the measured one; the range from low to high includes it.
By their numbers in this assay, from the lowest: compound 3; then compounds 2, 4 and 1 (each within the scatter of the next).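

With the (4-chlorophenyl)carbamoyl group held fixed, replacing tert-butyl on the ring nitrogen with cyanomethyl gives a 2.6-fold higher number from compound 3 to compound 4 (0.41 log units; beyond the scatter) in this assay and so does not keep the low number of compound 3. Exchanging oxetan-3-yl for cyanomethyl gives a 1.2-fold higher number from compound 2 to compound 4 (0.08 log units; within the scatter) and does not separate those two groups. Of the three groups on this nitrogen, only tert-butyl stands apart, with both of its steps beyond the scatter. Going by these compounds, whether isopropyl or cyclobutyl on this nitrogen would stay as low as tert-butyl remains open. Nothing available explains the gap between these groups.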